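The compounds below may be only part of what the source reports. "The series", "measured", "known", "first", "only" and "open" are said of these compounds alone.

Compound 1 `C/C(=N\NC(=O)C(C#N)C(=S)S)c1ccc(NS(=O)(=O)c2ccc(Cl)cc2)cc1`: in a functional assay on HepG2 cells (Homo sapiens) for cytotoxicity, read by sulforhodamine B assay, with a stated time of 48 h (a lower number here means a stronger inhibitor, a higher number a weaker inhibitor), compound 1 gives 17500 nM.
Compound 2 `CSC(SC)=C(C#N)C(=O)N/N=C(\C)c1ccc(NS(=O)(=O)c2ccc(Cl)cc2)cc1`: compound 2 gives 19400 nM.
Compound 3 `CCOC(=O)c1c(-c2ccc(C)cc2)c(C#N)c(=O)n(/N=C(\C)c2ccc(NS(=O)(=O)c3ccc(Cl)cc3)cc2)c1N`: compound 3 gives 8380 nM.

Of these three, compound 3 has the lowest number; compound 1 stands at a higher number and compound 2 higher still, and both gaps lie beyond the scatter, so compound 3 is the strongest inhibitor of the measured set. Compounds 1 and 2 differ only in a group on a carbonyl carbon, and the step of a 1.1-fold higher number from compound 1 to compound 2 (0.04 log units; within the scatter) lies within the scatter.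

Compound 4 `CCOC(=O)c1c(-c2ccc(OC)cc2)c(C#N)c(=O)n(/N=C(\C)c2ccc(NS(=O)(=O)c3ccc(Cl)cc3)cc2)c1N` is not yet measured. It differs from compound 3 by methoxy in place of methyl on an aromatic carbon. Among the measured compounds shown here, no measured step touches this part of the molecule: the single measured step, from compound 1 to compound 2, alters a group on a carbonyl carbon and is itself within the scatter, so it offers no guide to the present change. With nothing to set a direction, compound 4 is expected to land close to compound 3 in this assay, with a step of a 1.0-fold higher number from compound 3 to compound 4 (0.00 log units; within the scatter) estimated to stay within the scatter. Compound 4 is therefore estimated at 8400 nM, within a range from 4000 nM to 17000 nM.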

Compound 4, half-maximal inhibitory concentration: 61700 nM
Beside the measured number, compound 4's estimate is 7.3-fold (0.87 log units) below it, and the stated range ends below it.
By their numbers in this assay, from the lowest: compound 3; then compounds 1 and 2 (each within the scatter of the next); then compound 4.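

In this assay, among the compounds shown here, replacing methyl with methoxy on an aromatic carbon, para to a large group, gives a 7.4-fold higher number from compound 3 to compound 4 (0.87 log units; beyond the scatter), the only step so far that goes beyond the scatter. This position is therefore sensitive: a change as small as going from 4-methylphenyl to 4-methoxyphenyl makes compound 4 a clearly weaker inhibitor than compound 3. No measurement shown gives a reason for this loss.

With only methyl and methoxy seen at this place, the compounds cannot show whether the oxygen itself matters or whether any group other than methyl would weaken the compound in the same way. An ethyl group, which has no oxygen, and a hydroxyl group, a chlorine or an amine at the same place would each help to separate these possibilities.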